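Swapping a Benzoyl for a Silicon Group

A few compounds are considered here, and "the series" means these few. Any claim that something is new, unique, unknown or untested is made for them only; others in the source may bear on it.

Of the compounds shown here, two have been tested so far in a functional assay on HCT-116 cells (Homo sapiens) for antiproliferative activity, read by MTT assay, with a stated time of 48 h (on this read-out lower numbers stand for stronger inhibition and higher numbers for weaker inhibition), so far as this series goes. Compound 1 (`CC(C)(C)[Si](C)(C)OCC(CCO)n1cnc2c(Cl)nc(F)nc21`) gives a real number there (7780 nM). Compound 2 (`O=C(OCC(CCO)n1cnc2c(Cl)ncnc21)c1ccccc1`) reads (> 50000 nM), and this is only a limit and not a number.

Compound 3 (`CC(C)(C)[Si](C)(C)OCC(CCO)n1cnc2c(Cl)ncnc21`) has not yet been measured. It follows from compound 2 by a single change on an oxygen on a saturated carbon: the benzoyl leaves, and a group holding silicon and no ring enters (a group of 7 heavy atoms (6 carbon, 1 silicon; no ring) in place of a group of 8 heavy atoms (7 carbon, 1 oxygen; one six-membered aromatic ring of carbon only), on an oxygen on a saturated carbon).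

Among the compounds with values here, the only guide to this new group is compound 1, which carries it on the same oxygen and gives (7780 nM). On that basis, a clear move towards stronger inhibition is expected in this assay, beyond the usual scatter. Its exact size stays uncertain, since the starting point is only a limit. The estimated step runs (an at least 3.5-fold lower number from compound 2 to compound 3 (0.55 log units; beyond the scatter)) in that direction. Compound 3 is expected to give an estimated (14000 nM), within a range of 5000 nM to 40000 nM once it is tested.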

Compound 3, half-maximal inhibitory concentration: > 50000 nM
Compound 3: no number, only a limit; the forecaster's own chance of this, stated with the estimate: 15%; middle value at least 3.5-fold (0.55 log units) from the limit.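

In this assay, the swap of benzoyl for the silicon group on an oxygen on a saturated carbon cannot be read, because compound 2 and compound 3 both end at a limit of the assay and not at a number: the limit of > 50000 nM in this assay, at which 2 of the 3 values shown sit.

What the result does show comes from the other pair, which shares the silicon group and differs only by hydrogen in place of fluoro on an aromatic carbon: that change gives an at least 6.4-fold higher number from compound 1 to compound 3 (0.80 log units; beyond the scatter). So the silicon group alone does not bring a readable value in this assay, and among these two compounds the real number is found only with the fluoro present.

From the compounds shown here alone, how the benzoyl and silicon groups rank against each other stays open, since either compound could lie anywhere past the limit, and so does whether fluoro would bring a readable value to the benzoyl compound as well. Also unknown is whether another group on that aromatic carbon, such as an amine or a methyl, would keep the activity of compound 1, lose it, or improve on it.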